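Swapping the benzyl ring for a pyridinyl one

A few compounds are considered here, and "the series" means these few. Any claim that something is new, unique, unknown or untested is made for them only; others in the source may bear on it.

Compound 1 `CCC(NC(=O)C(CC(C)C)NC(=O)OCc1ccccc1)C(=O)C(=O)NCCCCCO`: 51 nM
Compound 2 `CCC(NC(=O)C(CC(C)C)NC(=O)OCc1ccccc1)C(=O)C(=O)NCc1ccccc1`: 350 nM
Compound 3 `CCC(NC(=O)C(CC(C)C)NC(=O)OCc1ccccc1)C(=O)C(=O)NCc1cc(OC)cc(OC)c1`: 22 nM

Three compounds share a core and differ only in the group on a saturated chain carbon bound to an amide-type nitrogen. In an assay on isolated protein (Oryctolagus cuniculus) for inhibition of Calpain-2 catalytic subunit (Homo sapiens) (on this read-out lower numbers stand for stronger inhibition and higher numbers for weaker inhibition), compound 3 gives the lowest number of the three; compound 1 sits nearest to it and compound 2 furthest, as a 2.3-fold lower number from compound 1 to compound 3 (0.37 log units; beyond the scatter) and a 16-fold lower number from compound 2 to compound 3 (1.20 log units; beyond the scatter) show. Compound 4 `CCC(NC(=O)C(CC(C)C)NC(=O)OCc1ccccc1)C(=O)C(=O)NCc1cccnc1` has not been measured. Its change from compound 3 is pyridin-3-yl in place of 3,5-dimethoxyphenyl on a saturated chain carbon bound to an amide-type nitrogen. The step that bears most directly on this change is the one from a plain phenyl to the dimethoxy-bearing ring, a 16-fold lower number from compound 2 to compound 3 (1.20 log units; beyond the scatter), a large gain. Pyridin-3-yl, with no methoxy groups, resembles phenyl more than it resembles 3,5-dimethoxyphenyl, so much of that gain is expected to be given back, though the extra acceptor in the ring has no measured precedent here. Compound 4 is therefore expected to show a modest rise, a 6.8-fold higher number from compound 3 to compound 4 (0.83 log units; beyond the scatter), landing between compound 3 and compound 2. The estimate for compound 4 is 150 nM, with a range of 50 nM to 500 nM.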

Compound 4, inhibition constant: 120 nM
Compound 4: middle estimate off by 1.3-fold (0.10 log units), on the high side; the range from low to high includes it.
By their numbers in this assay, from the lowest: compound 3; then compound 1; then compound 4; then compound 2.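

Replacing phenyl with pyridin-3-yl on a saturated chain carbon bound to an amide-type nitrogen is itself a gain in this assay (a 2.9-fold lower number from compound 2 to compound 4 (0.46 log units; beyond the scatter)), so a ring without methoxy groups need not sit at the weak end of this series. That gain recovers only part of what 3,5-dimethoxyphenyl holds (a 5.5-fold higher number from compound 3 to compound 4 (0.74 log units; beyond the scatter)), and pyridin-3-yl also stays behind the 4-hydroxybutyl chain (a 2.4-fold higher number from compound 1 to compound 4 (0.37 log units; beyond the scatter)). Nothing available accounts for these differences.

The compounds shown leave open whether one methoxy group on the phenyl ring would carry the gain seen with 3,5-dimethoxyphenyl, and how pyridin-2-yl or pyridin-4-yl compares with pyridin-3-yl. They also leave open whether methoxy groups on the pyridin-3-yl ring would add to its gain, and how a 4-aminobutyl chain compares with 4-hydroxybutyl.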